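Bromo in Place of Iodo: Expecting Compound 3

The compounds below may be only part of what the source reports. "The series", "measured", "known", "first", "only" and "open" are said of these compounds alone.

Measured compounds in this assay:
Compound 1, `CCOc1ccc(NC2=CC(=O)c3ncncc3C2=O)cc1`: 0.03 ug/mL
Compound 2, `O=C1C(Nc2ccc(I)cc2)=CC(=O)c2ncncc21`: 0.04 ug/mL

In a functional assay on XF498 cells (Homo sapiens) for cytotoxicity, read by MTT assay, with a stated time of 72 h (on this read-out higher numbers stand for weaker inhibition and lower numbers for stronger inhibition), compound 1 gives 0.03 ug/mL and compound 2 gives 0.04 ug/mL. Compound 2 carries the higher of the two numbers, but the step of a 1.3-fold higher number from compound 1 to compound 2 (0.12 log units; within the scatter) lies within the scatter, so the two values show no difference that can be relied upon. Both compounds share the same core and differ only in the group on the aromatic carbon para to a large group.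

Compound 3, `O=C1C(Nc2ccc(Br)cc2)=CC(=O)c2ncncc21`, differs from compound 2 by bromo in place of iodo on an aromatic carbon. Within the data shown here, the only measured step at this place, a 1.3-fold higher number from compound 1 to compound 2 (0.12 log units; within the scatter), swapped ethoxy for iodo and moved the number within the scatter. Among the measured compounds shown here, no measured pair swaps one halogen for another, so the expectation for compound 3 rests on that single step and on the smallness of the change, one heavy atom leaving and one entering with no change in donors, acceptors or charge. The expected step of no change at the digits printed from compound 2 to compound 3 (within the scatter) is therefore estimated to stay within the scatter. Compound 3 is estimated at 0.04 ug/mL, with a range from 0.015 ug/mL to 0.1 ug/mL.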

Compound 3, half-maximal inhibitory concentration: 0.03 ug/mL
The estimate for compound 3 lay 1.3-fold (0.12 log units) above the measured number, within the range that was stated.
By their numbers in this assay, from the lowest: compounds 1, 3 and 2 (each within the scatter of the next).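

Among these compounds, this is the first step at this place that swaps one halogen for another, and in this assay it is a 1.3-fold lower number from compound 2 to compound 3 (0.12 log units; within the scatter), so bromo and iodo cannot be told apart on this read-out. The comparison with the ethoxy compound gives no change at the digits printed from compound 1 to compound 3 (within the scatter), which means that ethoxy, iodo and bromo on this aromatic carbon now all stand within the scatter of one another, and the three compounds offer no basis for ranking these groups. Nothing available accounts for why these three groups read alike.

The compounds shown leave open whether this sameness reaches beyond these three groups, since an amine, a carboxylic acid, a longer alkoxy chain or a lighter halogen such as fluoro could still move the number well beyond the scatter at this same place. They also leave open how much the aromatic ring itself contributes to the values in this assay, as a compound with a hydrogen at this place or with the whole ring replaced by a simple alkyl chain is not among those shown here.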